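Cyclopentylamino for propylamino on the shared core

The source may report more compounds than this note shows. Statements on the series, on what has been measured and on what is new or still open speak of the compounds shown alone.

Compound 1 `CCCCCCCCOc1nc(N)nc2c1ncn2/C=C1/CC1(CO)CO` carries an octyloxy group on the core and compound 2 `Nc1nc(NC2CC2)c2ncn(/C=C3/CC3(CO)CO)c2n1` a cyclopropylamino group in that place. In an ADME assay on MOLT-3 cells (Homo sapiens) for cytotoxicity, with a stated time of 7 days (on this read-out higher numbers stand for lower toxicity in this test and lower numbers for higher toxicity in this test), compound 1 reaches only the limit of the assay, > 20000 nM. In this assay compound 2 likewise reaches only the limit, > 20000 nM. The step that the two limits leave unreadable from compound 1 to compound 2 therefore cannot be read, because the limit of > 20000 nM in this assay, at which 2 of the 3 values shown sit, fixes where both values sit and no number lies between them.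

Compound 3 `CCCNc1nc(N)nc2c1ncn2/C=C1/CC1(CO)CO` has no result reported in this assay, "not determined" (no result reported), so it stands nowhere on the measured numbers. Compound 4 `Nc1nc(NC2CCCC2)c2ncn(/C=C3/CC3(CO)CO)c2n1` differs from it in one place: cyclopentyl in place of propyl on a nitrogen on an aromatic ring. Among the compounds with values here, no measured step bears on a change at this nitrogen; the only measured pair, compound 1 and compound 2, shows two limits and no readable size. With both known values at the limit, compound 4 is expected to fall at or near that same limit rather than to show toxicity in this assay, estimated at 30000 nM with a range from 15000 nM to 60000 nM.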

Compound 4, half-maximal cytotoxic concentration: > 20000 nM
Compound 4: only a limit was reported; the forecaster's own chance of this, stated with the estimate: 75%; the middle value is on the limit's open side.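

No step can be read among compound 1, compound 2 and compound 4 in this assay, because each of them stops at a limit and gives no number: the limit of > 20000 nM in this assay, at which 3 of the 4 values shown sit.

The compounds shown leave open how the cyclopentylamino, cyclopropylamino and octyloxy compounds differ beyond that limit, and where compound 3 stands.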